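The source may report more compounds than this note shows. Statements on the series, on what has been measured and on what is new or still open speak of the compounds shown alone.

Working notes on the series. Compound 1 `CN(c1ccccc1)c1cnc(NCc2c(F)ccc3c2CCO3)n2cnnc12` has been run in a physicochemical assay for solubility, read by LC-MS, in phosphate buffer, with a stated time of 24 h, at pH 7.4; on this read-out higher numbers stand for higher solubility and lower numbers for lower solubility. For compound 1 the read-out is a limit of the assay, < 2000 nM, not a number. Compound 2 `CNC(=O)c1ncc(-c2cnc(NCc3c(F)ccc4c3CCO4)c3cn[nH]c(=O)c23)n1C` gives 5000 nM in this assay. Compound 3 `Cc1ncccc1-c1cnc(NCc2c(F)ccc3c2CCO3)n2c(=O)[nH]nc12` also returns only a limit of the assay, < 2000 nM. Where compound 1 stands among the three values therefore cannot be fixed more closely than its limit; it sits at the limit of < 2000 nM in this assay, at which 2 of the 3 values shown sit. Among the measured compounds shown here, no two measured compounds differ in a single place, so no measured step is available to calibrate this change.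

Compound 4 `CN(c1cccnc1)c1cnc(NCc2c(F)ccc3c2CCO3)n2cnnc12` differs from compound 1 by pyridin-3-yl in place of phenyl on a nitrogen on an aromatic ring.

With compound 1 known only as a limit, the step of an at least 1.5-fold higher number from compound 1 to compound 4 (0.17 log units; that floor lies within the scatter) is expected to be modest and in the direction of higher solubility, possibly not beyond the usual scatter. Compound 4 is estimated at 3000 nM in this assay, expected to fall between 1000 nM and 10000 nM, with a real chance that this assay again reports only a limit for it.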

Compound 4, solubility: 47000 nM
The estimate for compound 4 lay 16-fold (1.19 log units) below the measured number, and the stated range ends below it.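

In this assay, this place, a nitrogen on an aromatic ring, proves highly responsive to a single change of ring atom: pyridin-3-yl in place of phenyl gives an at least 23-fold higher number from compound 1 to compound 4 (1.37 log units; beyond the scatter). Among the compounds shown here, this is the first measured step, and it shows that the shared core can tolerate a large change in this read-out from one swap at this place. For compound 1 the read-out is a limit of the assay, which makes the step a floor and not a full size: the limit of < 2000 nM in this assay, at which 2 of the 4 values shown sit.

The compounds shown leave open whether pyridin-2-yl, pyridin-4-yl or a morpholine at this place would behave as pyridin-3-yl does. From the compounds shown here alone, whether the same swap carries over to the other compounds also remains open.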